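Dithiocarbamate-triazole series: urea variation on the methoxybenzyl member

A few compounds are considered here, and "the series" means these few. Any claim that something is new, unique, unknown or untested is made for them only; others in the source may bear on it.

Measured compounds:
compound 1, `CCN(C)C(=O)N1CCN(C(=S)SCc2cn(Cc3ccccc3F)nn2)CC1`, 19700 nM
compound 2, `COc1ccc(Cn2cc(CSC(=S)N3CCN(C(=O)NC(C)C)CC3)nn2)cc1`, > 128000 nM

Two compounds carry numbers in a functional assay on SMMC-7721 cells (Homo sapiens) for cytotoxicity, read by MTT assay, with a stated time of 72 h; on this read-out higher numbers stand for weaker inhibition and lower numbers for stronger inhibition. Compound 1 `CCN(C)C(=O)N1CCN(C(=S)SCc2cn(Cc3ccccc3F)nn2)CC1` gives 19700 nM in this assay. Compound 2 `COc1ccc(Cn2cc(CSC(=S)N3CCN(C(=O)NC(C)C)CC3)nn2)cc1` reaches only a limit of the assay in this assay, > 128000 nM, so no number stands for it, only a bound; this is the limit of > 128000 nM in this assay, at which 1 of the 2 values shown sits.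

Compound 3 `CCN(C)C(=O)N1CCN(C(=S)SCc2cn(Cc3ccc(OC)cc3)nn2)CC1` is the unmeasured member. It differs from compound 2 in one place: ethyl(methyl)amino in place of isopropylamino on a carbonyl carbon. Among the measured compounds shown here, compound 1 carries the same ethyl(methyl)carbamoyl group, and its value is the only number in the set.

For the measured compounds named here, no measured step fixes the size of a urea change here. Compound 2 sits at a limit, so any expected shift for compound 3 runs from that bound towards a number; the step from compound 2 to compound 3 is expected as an at least 2.1-fold lower number from compound 2 to compound 3 (0.32 log units; beyond the scatter), modest and towards stronger inhibition, with a real chance that only a limit is returned again. For compound 3 the expected value in this assay is 60000 nM, within 15000 nM to 200000 nM.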

Compound 3, half-maximal inhibitory concentration: > 128000 nM
Compound 3: a limit, no number; the forecaster's own chance of this, stated with the estimate: 45%; middle value at least 2.1-fold (0.32 log units) away from the limit.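

In this assay compound 3 stops at a limit, > 128000 nM, and gives no number, so the ethyl(methyl)carbamoyl group alone does not bring the 4-methoxyphenyl member to a measurable value. The change from isopropylcarbamoyl to ethyl(methyl)carbamoyl on this member cannot be read, because both compounds of the pair end at a limit: the limit of > 128000 nM in this assay, at which 2 of the 3 values shown sit.

Among the compounds shown here, with the ethyl(methyl)carbamoyl group held fixed, 4-methoxyphenyl in place of 2-fluorophenyl on a saturated chain carbon bound to an aromatic nitrogen gives an at least 6.4-fold higher number from compound 1 to compound 3 (0.81 log units; beyond the scatter), the first readable step and one that places the visible difference at the aryl group, not the urea.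

Still open is whether the urea change has any size on the 2-fluorophenyl member, where a number exists that could move, since the isopropylcarbamoyl group is shown only on the 4-methoxyphenyl member. Also open is how an unsubstituted phenyl or a 4-chlorophenyl would fall in this assay relative to the two aryl groups shown, and so whether the step belongs to the loss of the fluorine, the arrival of the methoxy group, or both.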